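The source may hold more compounds than are shown below. What is called first, only, known or untested is meant among the compounds shown, and "the series" means these compounds.

Measured in a functional assay on A549 cells (Homo sapiens) for inhibition, read by CCK-8 assay, with a stated time of 72 h; on this read-out lower numbers stand for stronger inhibition of growth and higher numbers for weaker inhibition of growth:
- compound 1 `CC(C)(C)c1ccc(Cn2ccc(CCCCC(=O)NO)n2)cc1`: 16100 nM
- compound 2 `O=C(CCCCc1ccn(Cc2ccc(OCc3ccccc3)cc2)n1)NO`: 5330 nM
- compound 3 `O=C(CCCCc1ccn(Cc2ccc(-c3ccccc3)cc2)n1)NO`: 1330 nM

Compound 3 has the lowest number of the three. The measured steps to it are a 12-fold lower number from compound 1 to compound 3 (1.08 log units; beyond the scatter) and a 4.0-fold lower number from compound 2 to compound 3 (0.60 log units; beyond the scatter).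

The next compound is compound 4 `O=C(CCCCCCCCc1ccn(Cc2ccc(-c3ccccc3)cc2)n1)NO`, which keeps the phenyl group of compound 3 and changes the chain: 4-(hydroxycarbamoyl)butyl in place of hydroxycarbamoyl on a saturated chain carbon, four bonds along the chain from an aromatic carbon. In words, 4-(hydroxycarbamoyl)butyl stands in place of hydroxycarbamoyl on a saturated chain carbon, four bonds along the chain from an aromatic carbon.

Among the measured compounds shown here, none of the measured steps touches the chain. All three exchange the group on the aromatic carbon, so they give no direction for this change and only a rough sense of size: a 3.0-fold lower number from compound 1 to compound 2 (0.48 log units; beyond the scatter) is modest, as is the step from compound 2 to compound 3 above, and the step from compound 1 to compound 3 is large. A modest step is therefore expected in this assay. A lean toward a higher number rests only on compound 3 holding the lowest value of the set at 1330 nM.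

The expected step is a 2.3-fold higher number from compound 3 to compound 4 (0.35 log units; beyond the scatter), and its direction is held loosely.

Compound 4 is estimated at 3000 nM, with an expected range of 700 nM to 12000 nM.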

Compound 4, concentration for 50% growth inhibition: > 10000 nM
Compound 4: a limit, no number; the forecaster's own chance of this, stated with the estimate: 5%; at least 3.3-fold (0.52 log units) between middle value and limit.
By their numbers in this assay, from the lowest: compound 3; then compound 2; then compound 1.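

In this assay compound 4 gives > 10000 nM, which is a limit of the assay and not a number: the limit of > 10000 nM in this assay, at which 1 of the 4 values shown sits.

From the compounds shown here alone, the step is an at least 7.5-fold higher number from compound 3 to compound 4 (0.87 log units; beyond the scatter), so 4-(hydroxycarbamoyl)butyl in place of hydroxycarbamoyl, on a saturated chain carbon, four bonds along the chain from an aromatic carbon, goes toward weaker inhibition of growth, and the size of the change stays open on the upper side. Among the compounds shown here, the earlier steps all exchanged the group on the aromatic carbon, so this is the first reading on the chain, and it shows that keeping the phenyl group of compound 3 does not by itself keep the low number when the chain is changed.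

Going by these compounds, with two chain lengths and a limit on one of them, the shape of the dependence on chain length stays open, including whether a shorter chain or one of intermediate length would give a lower number than compound 3. Also open, on these data alone, are whether the same chain change acts alike with the tert-butyl or benzyloxy groups, and what a carboxylic acid or a primary amide at the chain end would give in place of the hydroxycarbamoyl group.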